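Taking the propyl off the amide of compound 2

The source may hold more compounds than are shown below. What is called first, only, known or untested is meant among the compounds shown, and "the series" means these compounds.

Measured in a functional assay on Huh-7 cells (Homo sapiens) for antiproliferative activity, read by CCK-8 assay, with a stated time of 72 h; a higher number here means a weaker inhibitor of growth, a lower number a stronger inhibitor of growth:
Compound 1 `CCC1C(=O)N(C)c2cnc(-n3ccc4cc(C(=O)NC(C)C)ccc43)nc2N1c1ccn(C)n1`: 6740 nM
Compound 2 `CCCNC(=O)c1ccc2c(ccn2-c2ncc3c(n2)N(c2ccn(C)n2)C(CC)C(=O)N3C)c1`: 7280 nM
Compound 3 `CCC1C(=O)N(C)c2cnc(Nc3ccc(S(N)(=O)=O)cc3)nc2N1c1ccn(C)n1`: "not active" (no number reported)

Compound 2 stands level with compound 1 in this assay, and compound 3 gave no number. The move to compound 4 `CCC1C(=O)N(C)c2cnc(-n3ccc4cc(C(N)=O)ccc43)nc2N1c1ccn(C)n1` is hydrogen in place of propyl on an amide-type nitrogen. Among the measured compounds shown here, one measured step bears on it, a 1.1-fold higher number from compound 1 to compound 2 (0.03 log units; within the scatter), which exchanges isopropyl for propyl on that same nitrogen. That step never removes the chain, so it is only a weak guide. No shift beyond the scatter is therefore expected, though with wide uncertainty. The expected step is a 1.0-fold lower number from compound 2 to compound 4 (0.02 log units; within the scatter) in this assay. The estimate for compound 4 is 7000 nM, within an expected range from 2500 nM to 20000 nM here.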

Compound 4, concentration for 50% growth inhibition: "not active" (no number reported)
Nothing numeric was reported for compound 4, and the estimate cannot be compared.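

Among the compounds shown here, compound 4 was reported as "not active" in this assay with no number, and no step from compound 2 to compound 4 can be read. No available evidence bears on this result. The compounds shown leave open how far replacing propyl with hydrogen on the amide nitrogen shifts growth inhibition.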